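This account rests on a few compounds, and the source may have more. Where it says the series, first, only, none or still open, it means among the compounds named here.

Measured so far:
compound 1, `Oc1ccccc1/C=N/c1nnc(SCc2nnc(-c3ccc(Cl)cc3)o2)s1`, 7550 nM
compound 2, `Oc1ccccc1/C=N/c1nnc(SCc2nnc(-c3ccc(Br)cc3)o2)s1`, 8320 nM

Both numbers come from a functional assay on MCF7 cells (Homo sapiens) for inhibition, read by CCK-8 assay; a higher number here means a weaker inhibitor, a lower number a stronger inhibitor. Compound 2 holds the highest of the two numbers, with compound 1 as its nearest neighbour at a small distance that falls within the scatter. For the measured compounds named here, the only step joining measured compounds, a 1.1-fold higher number from compound 1 to compound 2 (0.04 log units; within the scatter), swaps one halogen for another on the ring that hangs from the five-membered ring with two nitrogens and one oxygen, and it moves the number by no more than the scatter.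

Compound 3, `Cc1cccc(-c2nnc(CSc3nnc(/N=C/c4ccccc4O)s3)o2)c1`, has not yet been measured. It differs from compound 2 by 3-methylphenyl in place of 4-bromophenyl on an aromatic carbon. Going by the values given here, no measured step replaces a halogen-bearing phenyl by a methyl-bearing one, so the halogen swap is the only guide, and that guide says this position tolerated one exchange without a shift beyond the scatter. On that basis the step from compound 2 to compound 3 in this assay is expected to be small, a 1.1-fold higher number from compound 2 to compound 3 (0.03 log units; within the scatter), in either direction or none at all. Compound 3 is therefore estimated at 9000 nM, with a plausible range from 3000 nM to 30000 nM.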

Compound 3, half-maximal inhibitory concentration: 11600 nM
Compound 3: the middle estimate sits 1.3-fold (0.11 log units) below what was measured; measured number inside the range.
By their numbers in this assay, from the lowest: compounds 1, 2 and 3 (each within the scatter of the next).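

The earlier pair exchanged only one halogen for another, whereas this change replaces the halogen with a methyl group and alters the substituent's location on the phenyl ring, as the names 4-bromophenyl and 3-methylphenyl show. Even so, in this assay, the result stays within the scatter when measured against either halogen compound (a 1.4-fold higher number from compound 2 to compound 3 (0.14 log units; within the scatter); a 1.5-fold higher number from compound 1 to compound 3 (0.19 log units; within the scatter)), so this larger exchange on the five-membered aromatic ring with 2 nitrogen and 1 oxygen separates none of the three compounds. Nothing available here explains this result, so no cause can be assigned to it.

Because compound 3 differs from compound 2 in both the substituent and its location, the compounds shown cannot separate the contribution of either, and 4-methylphenyl would be needed to make that comparison. All three compounds also carry a substituted phenyl at this position and share the rest of the core, leaving open what an amine, a carboxylic acid or a longer chain in place of that phenyl would give in this assay.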